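The source may report more compounds than this note shows. Statements on the series, on what has been measured and on what is new or still open speak of the compounds shown alone.

Working notes on the series. Compound 1 `CC1CCC(=NNc2c(Cl)cccc2Cl)c2ncc(C(=O)O)c(=O)n21` is measured in a functional assay on the whole organism with Rattus norvegicus as the target; a lower number here means that less compound is needed, a higher number that more compound is needed for the effect. In this assay compound 1 gives > 100 umol/kg, a limit of the assay and not a number. Compound 2 `CC1CCC(=NNc2ccc(Br)cc2Cl)c2ncc(C(=O)O)c(=O)n21` carries 4-bromo-2-chlorophenyl in place of 2,6-dichlorophenyl on an amine nitrogen. In this assay compound 2 gives > 100 umol/kg, again a limit. Compound 3 `Cc1cccc(Cl)c1NN=C1CCC(C)n2c1ncc(C(=O)O)c2=O` carries methyl in place of chloro on an aromatic carbon. In this assay compound 3 gives > 100 umol/kg, also a limit. Compound 3 thus stands at the limit of > 100 umol/kg in this assay, at which 3 of the 3 values shown sit, with no number of its own and no ordering among the three possible. The steps a step that the two limits leave unreadable from compound 1 to compound 2, a step that the two limits leave unreadable from compound 1 to compound 3 and a step that the two limits leave unreadable from compound 2 to compound 3 are all unreadable, since each runs between two limits.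

Compound 4 `Cc1cc(NN=C2CCC(C)n3c2ncc(C(=O)O)c3=O)ccc1Br` differs from compound 3 in one place: 4-bromo-3-methylphenyl in place of 2-chloro-6-methylphenyl on an amine nitrogen. Within the data shown here, none of the measured steps bears readably on this change; the aryl group on the amine nitrogen has been varied in each of the measured compounds without a number emerging. The step to compound 4 a step that the limit leaves unreadable from compound 3 to compound 4 is therefore expected to be small or not readable, with a further limit the most likely outcome. Compound 4 is expected to give 150 umol/kg in this assay, within a range from 40 umol/kg to 600 umol/kg.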

Compound 4, dose for 50% inhibition: > 100 umol/kg
Compound 4: a limit, no number (the forecaster's own chance of this, stated with the estimate: 75%); the middle value does not contradict the limit.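

Among these compounds, no step to compound 4 from compound 1, compound 2 or compound 3 can be read in this assay, because each runs between two limits: the limit of > 100 umol/kg in this assay, at which 4 of the 4 values shown sit. The compounds shown leave open how compound 1, compound 2, compound 3 and compound 4 order among themselves, and whether the aryl group on the amine nitrogen affects the read-out in this assay at all.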